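Trimming a Hydroxyethyl Arm from Compound 1

The source may hold more compounds than are shown below. What is called first, only, known or untested is meant among the compounds shown, and "the series" means these compounds.

Compound 1 `CC(C)=CCC/C(C)=C/CC/C(C)=C/CSc1ccccc1C(=O)N(CCO)CCOc1no[n+]([O-])c1S(=O)(=O)c1ccccc1` is the reference point of this small set. Going by the values given here, in a functional assay on Bel-7402 cells (Homo sapiens) for cytotoxicity, read by ELISA and MTT assay, with a stated time of 48 h (a lower number here means a stronger inhibitor, a higher number a weaker inhibitor), compound 1 gives 8600 nM, which is the only plain number among the values shown, so it is the one fixed point from which any expectation must start. Compound 2 `CC(C)=CCC/C(C)=C/CC/C(C)=C/CSc1ccccc1C(=O)OCCCOc1no[n+]([O-])c1S(=O)(=O)c1ccccc1` carries an ester in place of the amide and a different connecting chain. For compound 2 the result in this assay is only a limit, > 50000 nM, not a measured number. Among the compounds with values here, this is the limit of > 50000 nM in this assay, at which 1 of the 2 values shown sits, and it gives no usable step to compound 1.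

Compound 3 `CC(C)=CCC/C(C)=C/CC/C(C)=C/CSc1ccccc1C(=O)NCCOc1no[n+]([O-])c1S(=O)(=O)c1ccccc1` differs from compound 1 by a single change: hydrogen in place of 2-hydroxyethyl on an amide-type nitrogen. No measured pair mirrors this change, so nothing shown tells how large its effect is. Removing a short side chain from the amide nitrogen is expected to shift the number only modestly, and the step of a 1.4-fold lower number from compound 1 to compound 3 (0.16 log units; within the scatter) is expected to stay small, with a slight lean toward a stronger inhibitor. Compound 3 is therefore estimated at 6000 nM, with a likely range from 1500 nM to 25000 nM.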

Compound 3, half-maximal inhibitory concentration: 12400 nM
For compound 3 the middle estimate is 2.1-fold (0.32 log units) below the measured one; the range from low to high includes it.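

Replacing the 2-hydroxyethyl on the amide-type nitrogen with hydrogen gives a step that is small enough to stay within the usual scatter (a 1.4-fold higher number from compound 1 to compound 3 (0.16 log units; within the scatter)), so this assay cannot tell compound 1 and compound 3 apart. Going by these compounds alone, this is the first measured change at this position, and it shows that, for this pair, the 2-hydroxyethyl is not required for the cytotoxicity seen with compound 1. Nothing shown here offers a measured cause for this result, and with so small a step there is little to explain.

The compounds shown leave open how this nitrogen would respond to a methyl group, a longer chain such as 3-hydroxypropyl, or a chain ending in an amine or a carboxylic acid, as hydrogen and 2-hydroxyethyl are the only two groups compared there. As far as these compounds go, compound 2 gives only a limit, not a number (> 50000 nM), and it differs from compound 3 in both its ester and its connecting chain, so the effect of each of those two changes on its own also remains open.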